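From pyridin-2-yl to pyridin-4-yl on compound 3

The compounds below may be only part of what the source reports. "The series", "measured", "known", "first", "only" and "open" are said of these compounds alone.

Of the compounds shown here, three built on a closely related core have been tested in a functional assay (Homo sapiens) for antiproliferative activity; on this read-out higher numbers stand for weaker inhibition of growth and lower numbers for stronger inhibition of growth. Compound 1 (`Cc1cn2c(/C=N/NC(=N)N)c(-c3ccncc3)nc2s1`) gives 19500 nM, compound 2 (`Cc1sc2nc(-c3ccncc3)c(/C=N/NC(=N)N)n2c1C`) gives 38000 nM and compound 3 (`N=C(N)N/N=C/c1c(-c2ccccn2)nc2sc(Cl)cn12`) gives 7760 nM. Compound 3 has the lowest number of the three, and its gap to each of the others lies beyond the scatter, so it inhibits growth most strongly in this small set.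

Compound 4 (`N=C(N)N/N=C/c1c(-c2ccncc2)nc2sc(Cl)cn12`) is the same as compound 3 except for one swap, pyridin-4-yl in place of pyridin-2-yl on an aromatic carbon. The atoms stay the same, but they are joined differently.

Going by the values given here, no measured step makes this swap. Among the compounds with values here, the only single-place step, a 1.9-fold higher number from compound 1 to compound 2 (0.29 log units; within the scatter), is a methyl in place of hydrogen, so it says little about the pyridine. The indirect hint is that pyridin-4-yl is also present in compound 1, at 19500 nM, and in compound 2, at 38000 nM. Both numbers are higher than that of compound 3, yet these compounds also differ from it elsewhere on the core. A modest rise is therefore expected, close to the edge of the scatter, and the estimated step is a 1.7-fold higher number from compound 3 to compound 4 (0.22 log units; within the scatter). For compound 4 the estimated value is 13000 nM, with an expected range from 4500 nM to 35000 nM.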

Compound 4, concentration for 50% growth inhibition: 5890 nM
Compound 4: middle estimate off by 2.2-fold (0.34 log units), on the high side; the range from low to high includes it.
By their numbers in this assay, from the lowest: compounds 4 and 3 (each within the scatter of the next); then compounds 1 and 2 (each within the scatter of the next).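

In this assay, pyridin-4-yl in place of pyridin-2-yl on this aromatic carbon gives a 1.3-fold lower number from compound 3 to compound 4 (0.12 log units; within the scatter), so the two groups cannot be told apart here, although their atoms are joined differently. Going by these compounds alone, with pyridin-4-yl held fixed, chloro in place of methyl on an aromatic carbon gives a 3.3-fold lower number from compound 1 to compound 4 (0.52 log units; beyond the scatter), a modest step, but the first single-place step in this set that lies beyond the scatter. In these pairs, then, the chloro for methyl swap shifts the number more clearly than the pyridine swap does, although nothing at hand explains either step.

The compounds shown leave open whether this position would keep the same level of growth inhibition with pyridin-3-yl, with a plain phenyl ring, or with a group of a different kind, such as an amine or a carboxylic acid. They also leave open whether the chloro step would hold with pyridin-2-yl in place of pyridin-4-yl, and whether bromo or a plain hydrogen at the chloro position would give a similar number.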